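Shifting the Ether-Bearing Ring on a Shared Piperazine Core

This account rests on a few compounds, and the source may have more. Where it says the series, first, only, none or still open, it means among the compounds named here.

Measured compounds:
compound 1, `CCCOc1ccnc(N2CCN(c3nc(N)c4cc(OC)c(OC)cc4n3)CC2)n1`, 0.32 nM
compound 2, `COc1cc2nc(N3CCN(c4nccc(-c5ccccc5)n4)CC3)nc(N)c2cc1OC`, 1.66 nM
compound 3, `COc1cc2nc(N3CCN(c4ccnc(Oc5ccccc5)n4)CC3)nc(N)c2cc1OC`, 0.24 nM

Three compounds share one core and differ only in the group carried on the amine nitrogen of the six-membered non-aromatic ring. In an assay on brain for binding affinity to Adrenergic receptor alpha-1 (Rattus norvegicus) (a higher number here means a weaker inhibitor, a lower number a stronger inhibitor), compound 1 gives 0.32 nM, which places it second highest of the three numbers. Its nearest neighbour is compound 3 at 0.24 nM; the two values lie within the scatter of each other. The furthest is compound 2 at 1.66 nM, and the step of a 5.2-fold higher number from compound 1 to compound 2 (0.71 log units; beyond the scatter) is a modest one in this assay.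

Compound 4, `COc1cc2nc(N3CCN(c4ccc(OC(C)C)nn4)CC3)nc(N)c2cc1OC`, is not yet measured. It differs from compound 1 in one place: 6-isopropoxypyridazin-3-yl in place of 4-propoxypyrimidin-2-yl on an amine nitrogen in a ring. Going by the values given here, no measured step bears directly on this change; the only measured step, from compound 1 to compound 2, swaps a propoxy for a phenyl and is of a different kind. Compounds 1 and 3 both carry an oxygen-linked group on the ring attached to that nitrogen and both sit at the low end, while compound 2, lacking one, sits higher. On that slim basis compound 4 is expected to stay close to compound 1, with an estimated step of a 1.3-fold higher number from compound 1 to compound 4 (0.10 log units; within the scatter) that lies within the scatter. Compound 4 is therefore estimated at 0.4 nM, within a range from 0.15 nM to 1.2 nM.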

Compound 4, inhibition constant: 0.29 nM
Estimate against measurement, compound 4: 1.4-fold (0.14 log units) above, and the stated range covers the measured number.
By their numbers in this assay, from the lowest: compounds 3, 4 and 1 (each within the scatter of the next); then compound 2.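

In this assay, 6-isopropoxypyridazin-3-yl in place of 4-propoxypyrimidin-2-yl on the amine nitrogen in the ring gives a 1.1-fold lower number from compound 1 to compound 4 (0.04 log units; within the scatter) and so stays within the scatter, although both the aromatic ring and the ether chain differ. The earlier step, phenyl in place of propoxy, moved the number beyond the scatter; this one shows that at this position the same atoms can be joined differently, with the same counts of heavy atoms, hydrogen-bond donors and hydrogen-bond acceptors, and the two compounds cannot be told apart in this binding measurement. Nothing available here speaks to why the two groups read alike.

The change alters the aromatic ring and the ether chain together, so the compounds shown leave open what each part contributes on its own and whether the two parts offset each other. Also open, from the compounds shown here alone, is how the number responds when the isopropoxy group gives way to an amine, a carboxylic acid or a longer chain such as hexyloxy.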